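The compounds below may be only part of what the source reports. "The series", "measured", "known", "first", "only" and "open" are said of these compounds alone.

Of the compounds shown here, three built on one shared core have been measured in a functional assay on isolated protein for inhibition of Glucose-dependent insulinotropic receptor (Homo sapiens), read by HTRF and cAMP accumulation; a higher number here means that more compound is needed for the effect, a lower number that less compound is needed. Compound 1 `Cc1nc(S(C)(=O)=O)ccc1Oc1ncnc(OC2CCN(C(=O)OC(C)F)CC2)c1F` gives 65.5 nM, compound 2 `Cc1nc(S(C)(=O)=O)ccc1Oc1ncnc(OC2CCN(C(=O)O[C@H](C)C(F)(F)F)CC2)c1F` gives 9.2 nM, and compound 3 `Cc1nc(S(C)(=O)=O)ccc1Oc1ncnc(OC2CCN(C(=S)OC(C)C)CC2)c1F` gives 69.9 nM, the highest of the three numbers, although its gap from compound 1 stays within the scatter, a 1.1-fold higher number from compound 1 to compound 3 (0.03 log units; within the scatter), while its gap from compound 2 does not, a 7.6-fold higher number from compound 2 to compound 3 (0.88 log units; beyond the scatter). Compound 4 `Cc1nc(S(C)(=O)=O)ccc1Oc1ncnc(OC2CCN(C(=O)C(C)(F)F)CC2)c1F` differs from compound 3 by a group of 6 heavy atoms (3 carbon, 1 oxygen, 2 fluorine; no ring) in place of a group of 6 heavy atoms (4 carbon, 1 oxygen, 1 sulfur; no ring), on an amine nitrogen in a ring. Within the data shown here, no measured step swaps exactly these pieces; the nearest guides are a 1.1-fold higher number from compound 1 to compound 3 (0.03 log units; within the scatter), an exchange at the same nitrogen that changed nothing beyond the scatter, and a 7.1-fold lower number from compound 1 to compound 2 (0.85 log units; beyond the scatter), where a group carrying more fluorine went with a clearly lower number. Compound 4 is therefore expected to show a modestly lower number, a 2.3-fold lower number from compound 3 to compound 4 (0.37 log units; beyond the scatter), estimated at 30 nM with a range from 8 nM to 120 nM.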

Compound 4, half-maximal effective concentration: 37 nM
For compound 4 the middle estimate is 1.2-fold (0.09 log units) below the measured one; low and high end bracket the measured number.
By their numbers in this assay, from the lowest: compound 2; then compounds 4, 1 and 3 (each within the scatter of the next).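

In this assay, the (1,1-difluoroethyl)carbonyl group on the amine nitrogen of compound 4 cannot be told apart from the groups at that nitrogen in compound 3 (a 1.9-fold lower number from compound 3 to compound 4 (0.28 log units; within the scatter)) or compound 1 (a 1.8-fold lower number from compound 1 to compound 4 (0.25 log units; within the scatter)), even though it has one hydrogen-bond acceptor fewer than the group of compound 3. Only compound 2, with its 1-(trifluoromethyl)ethoxy group on the carbonyl carbon, stands clearly apart (a 4.0-fold higher number from compound 2 to compound 4 (0.60 log units; beyond the scatter)). Nothing available explains this gap. Going by these compounds, whether an amine in place of that oxygen, or a cyclopropyl group on the carbonyl carbon, would match compound 2 remains open.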